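Carbamate Leaving Groups: Methoxy Gives Way to Fluoro

A few compounds are considered here, and "the series" means these few. Any claim that something is new, unique, unknown or untested is made for them only; others in the source may bear on it.

Compounds measured so far in an assay on isolated protein for inhibition of Monoglyceride lipase (Rattus norvegicus), read by fluorescence, with stated times of 15 min and 3 h; on this read-out lower numbers stand for stronger inhibition and higher numbers for weaker inhibition:
compound 1, `N#Cc1ccnc(OC(=O)N2CCC(C(c3ccccc3)c3ccccc3)CC2)c1`: 20.1 nM
compound 2, `COc1cc(C#N)cc(OC(=O)N2CCC(C(c3ccccc3)c3ccccc3)CC2)c1`: 98 nM

Going by the values given here, of these two, compound 2 stands at the higher number, and the single measured step that links them is a 4.9-fold higher number from compound 1 to compound 2 (0.69 log units; beyond the scatter). Compound 3 `N#Cc1cc(F)cc(OC(=O)N2CCC(C(c3ccccc3)c3ccccc3)CC2)c1` has not yet been measured in this assay. It differs from compound 2 by fluoro in place of methoxy on an aromatic carbon.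

Among the compounds with values here, no measured step alters a substituent on that ring while the rest of the molecule is held fixed. Within the data shown here, the one step recorded exchanges the whole aromatic ring bearing the cyano group, so it says nothing direct about replacing methoxy with fluoro. The data therefore give no ground for expecting a move beyond the scatter in either direction, and the expected number for compound 3 is close to that of compound 2. The step this expectation implies is a 1.2-fold lower number from compound 2 to compound 3 (0.09 log units; within the scatter). On that basis compound 3 is estimated at 80 nM, with a range from 30 nM to 250 nM.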

Compound 3, half-maximal inhibitory concentration: 105 nM
For compound 3 the middle estimate is 1.3-fold (0.12 log units) below the measured one; measured number inside the range.
By their numbers in this assay, from the lowest: compound 1; then compounds 2 and 3 (each within the scatter of the next).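

In this assay, going by these compounds alone, fluoro in place of methoxy on an aromatic carbon gives a 1.1-fold higher number from compound 2 to compound 3 (0.03 log units; within the scatter): this is the first direct reading of a substituent at this place, and the two groups cannot be told apart, although the change removes a heavy atom and the hydrogen-bond acceptor counted for methoxy. The ring exchange now has a second reading, a 5.2-fold higher number from compound 1 to compound 3 (0.72 log units; beyond the scatter), which lies beyond the scatter just as a 4.9-fold higher number from compound 1 to compound 2 (0.69 log units; beyond the scatter) does, so the 4-cyanopyridin-2-yl carbamate keeps a clear lead over both the 3-cyano-5-methoxyphenyl and the 3-cyano-5-fluorophenyl carbamates. No measured evidence is available to explain either the flat step or the gap to compound 1.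

With only methoxy and fluoro shown at this place, it remains open whether an amine, a carboxylic acid or a longer alkoxy chain on the same aromatic carbon would also leave the number unmoved. Going by these compounds, it is equally open whether methoxy or fluoro added to the 4-cyanopyridin-2-yl ring would show the same indifference, or whether that ring responds differently to such a substituent.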